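Aryl urea series: methoxy in place of trifluoromethyl

The source may report more compounds than this note shows. Statements on the series, on what has been measured and on what is new or still open speak of the compounds shown alone.

Compound 1, `Cc1ccccc1NC(=O)N[C@@H](C)c1ccccc1`: in an ADME assay on the whole organism with Oryza sativa as the target, tested at 0.1 uM (on this read-out lower numbers stand for a stronger effect and higher numbers for a weaker effect at the one concentration tested), compound 1 gives 100%.
Compound 2, `CC(C)c1ccccc1NC(=O)N[C@@H](C)c1ccccc1`: in this assay compound 2 gives 99%.
Compound 3, `C[C@H](NC(=O)Nc1ccccc1C(F)(F)F)c1ccccc1`: in this assay compound 3 gives 97%.

The three measured compounds share one core and differ only in the group on one aromatic carbon of the ring bearing the urea nitrogen. Compound 3 is the reference for the next step; its number differs from compound 2 by a number 2 percentage points lower from compound 2 to compound 3 (within the scatter) and from compound 1 by a number 3 percentage points lower from compound 1 to compound 3 (within the scatter), and both of these steps lie within the scatter of the measurement. The remaining step, a number 1 percentage points lower from compound 1 to compound 2 (within the scatter), is also within the scatter. All three numbers therefore read as one level.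

Compound 4, `COc1ccccc1NC(=O)N[C@@H](C)c1ccccc1`, is not yet measured. It differs from compound 3 as follows: methoxy in place of trifluoromethyl on an aromatic carbon.

Among the compounds with values here, the steps that bear on this change are the two swaps at the same aromatic carbon, a number 3 percentage points lower from compound 1 to compound 3 (within the scatter) and a number 2 percentage points lower from compound 2 to compound 3 (within the scatter), neither of which moved the read-out beyond the scatter. Nothing in the series shows a group at this carbon shifting this assay, so no step beyond the scatter is expected for compound 4 either. Compound 4 is therefore expected to give about 97% in this assay, between 88% and 100%, which is the expected step of no change at the digits printed from compound 3 to compound 4 (within the scatter).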

Compound 4, a percentage reported as activity, at one concentration (the size of the read-out at that concentration, not a potency): 98%
Compound 4: middle estimate off by 1 percentage points, on the low side, and the stated range covers the measured number.
By their numbers in this assay, from the lowest: compounds 3, 4, 2 and 1 (each within the scatter of the next).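

Methoxy puts a hydrogen-bond acceptor on this aromatic carbon, ortho to a large group, where trifluoromethyl has none, yet in this assay the swap gives only a small shift (a number 1 percentage points higher from compound 3 to compound 4 (within the scatter)), so adding this acceptor in place of trifluoromethyl leaves the read-out at the same level. Within the data shown here, the comparisons with the two alkyl groups agree (a number 1 percentage points lower from compound 2 to compound 4 (within the scatter); a number 2 percentage points lower from compound 1 to compound 4 (within the scatter)), and compounds 1, 2, 3 and 4 now read as one level across four different groups at this carbon, with no compound in the set going against that. No measurement available here offers a reason for this flat result.

Going by these compounds, whether an amine, a carboxylic acid or a longer chain such as a butoxy group at this aromatic carbon would move this assay beyond the scatter stays open, as does the effect of a change elsewhere on the shared core. These compounds also leave open how they would read at other concentrations, since a single concentration gives the size of the read-out and not a potency.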